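Replacing the 3-Nitrophenyl Group with 2-Methylphenyl

The source may report more compounds than this note shows. Statements on the series, on what has been measured and on what is new or still open speak of the compounds shown alone.

Three analogues share one core. Compound 1 `N#Cc1c(Nc2cccc(Cl)c2)nc(SCc2cn(Cc3ccccc3Cl)nn2)nc1-c1ccccc1` carries a 3-chlorophenyl group and in a functional assay on MCF7 cells (Homo sapiens) for inhibition, read by MTT assay, with a stated time of 72 h (a lower number here means a stronger inhibitor, a higher number a weaker inhibitor), compound 1 gives 12000 nM. Compound 2 `COc1ccccc1Nc1nc(SCc2cn(Cc3ccccc3Cl)nn2)nc(-c2ccccc2)c1C#N` carries a 2-methoxyphenyl group, and in this assay compound 2 gives 6170 nM; the change is a 1.9-fold lower number from compound 1 to compound 2 (0.29 log units; within the scatter). Compound 3 `N#Cc1c(Nc2cccc([N+](=O)[O-])c2)nc(SCc2cn(Cc3ccccc3Cl)nn2)nc1-c1ccccc1` carries a 3-nitrophenyl group. In this assay compound 3 gives only a limit, > 64000 nM. Compound 3 therefore stands at the weak end of the three, with an at least 5.3-fold higher number from compound 1 to compound 3 (0.72 log units; beyond the scatter) and an at least 10-fold higher number from compound 2 to compound 3 (1.01 log units; beyond the scatter), both steps resting on (the limit of > 64000 nM in this assay, at which 1 of the 3 values shown sits).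

Compound 4 `Cc1ccccc1Nc1nc(SCc2cn(Cc3ccccc3Cl)nn2)nc(-c2ccccc2)c1C#N` differs from compound 3 in one place: 2-methylphenyl in place of 3-nitrophenyl on a nitrogen on an aromatic ring. For the measured compounds named here, two measured steps bear on this. The step from compound 2 to compound 3 shows that exchanging an ortho-substituted phenyl group for the 3-nitrophenyl group costs a large amount, and the step from compound 1 to compound 3 points the same way. Reversing that exchange toward a 2-methylphenyl group is expected to recover most of it, so in this assay compound 4 is expected to show an at least 8.0-fold lower number from compound 3 to compound 4 (0.90 log units; beyond the scatter). Because compound 2 gives 6170 nM, compound 4 is estimated at 8000 nM, within a range from 3000 nM to 30000 nM.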

Compound 4, half-maximal inhibitory concentration: 7950 nM
Beside the measured number, compound 4's estimate is 1.0-fold (0.00 log units) above it; the measured number falls inside the stated range.
By their numbers in this assay, from the lowest: compounds 2, 4 and 1 (each within the scatter of the next). At a limit, above all of these: compound 3.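

In this assay, the result shows that the weak reading of compound 3 is not shared by this further group on the nitrogen, with an at least 8.0-fold lower number from compound 3 to compound 4 (0.90 log units; beyond the scatter). Compound 3 stands at a limit, so that step gives only a minimum size: the limit of > 64000 nM in this assay, at which 1 of the 4 values shown sits. The new group also does not separate from the two before it, with a 1.3-fold higher number from compound 2 to compound 4 (0.11 log units; within the scatter) and a 1.5-fold lower number from compound 1 to compound 4 (0.18 log units; within the scatter), so methyl in place of methoxy on an aromatic carbon and 2-methylphenyl in place of 3-chlorophenyl on this nitrogen both stay within the scatter, and among the four compounds only compound 3 stands apart.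

Going by these compounds, it remains open how a 2-nitrophenyl or a 3-methylphenyl group on this nitrogen would read in this assay, and such a pair would tell whether the gap follows the nitro group itself or where it stands on the phenyl ring. On these data alone, it is also open whether a phenyl ring carrying an amine or a carboxylic acid would fall with compounds 1, 2 and 4 or with compound 3.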